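Amide substituent swap on the shared core, compound 1 to compound 4

This account rests on a few compounds, and the source may have more. Where it says the series, first, only, none or still open, it means among the compounds named here.

Among the compounds with values here, the three measured members share one core carrying two amide links. Compound 1 `COc1cccc(OC)c1C(=O)Nc1c[nH]nc1C(=O)Nc1ccncc1` bears a pyridin-4-yl on the second amide nitrogen; compound 2 `COc1ccccc1C(=O)Nc1c[nH]nc1C(=O)N[C@H]1CC[C@H](OC)CC1` and compound 3 `CO[C@H]1CC[C@H](NC(=O)c2n[nH]cc2NC(=O)c2ncoc2-c2ccccc2)CC1` carry other groups there and on the first amide. In an ADME assay on MRC5 cells (Homo sapiens) for inhibition, with a stated time of 72 h (a higher number here means that more compound is needed for the effect, a lower number that less compound is needed), compound 1 gives > 50000 nM, which is a limit of the assay and not a number (the limit of > 50000 nM in this assay, at which 1 of the 3 values shown sits). In this assay compound 2 gives 1500 nM. In this assay compound 3 gives 28000 nM. Within the data shown here, no pair of measured compounds differs in a single place, so no measured step is available.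

Compound 4 `COc1cccc(OC)c1C(=O)Nc1c[nH]nc1C(=O)NCc1ncccc1C` has not been measured in this assay. It differs from compound 1 in one place: (3-methylpyridin-2-yl)methyl in place of pyridin-4-yl on an amide-type nitrogen. The change sits on an amide-type nitrogen whose other neighbour is the carbonyl carbon. Since compound 1 stands only at a limit, the direction of the step cannot be read from the data; a reading within the scatter, or a limit again, is as likely as any shift.

Compound 4 is estimated to give about 40000 nM in this assay, between 8000 nM and 100000 nM. The expected step is an at least 1.2-fold lower number from compound 1 to compound 4 (0.09 log units; that floor lies within the scatter), an estimate against a limit only.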

Compound 4, half-maximal effective concentration: > 50000 nM
Compound 4 gave a limit, no number; the forecaster's own chance of this, stated with the estimate: 50%; middle value at least 1.2-fold (0.09 log units) from the limit.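

Compound 1 and compound 4 both stand at a limit of this assay, not at a number, so no step between them can be read: the limit of > 50000 nM in this assay, at which 2 of the 4 values shown sit.

Still open, as far as these compounds go, is whether (3-methylpyridin-2-yl)methyl in place of pyridin-4-yl on the amide-type nitrogen shifts the value in this assay in either direction.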